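Bromo in place of fluoro on compound 2

The compounds below may be only part of what the source reports. "The series", "measured", "known", "first", "only" and "open" are said of these compounds alone.

In a functional assay on DU-145 cells (Homo sapiens) for cytotoxicity, read by trypan blue exclusion, with a stated time of 96 h (on this read-out higher numbers stand for weaker inhibition and lower numbers for stronger inhibition), compound 2 `COc1cc(OC)c(/C=C/S(=O)(=O)Cc2ccc(OC)c(NC(C(=O)O)c3ccc(F)cc3)c2)c(OC)c1` gives 150 nM. Among the compounds with values here, the only other measured compound, compound 1 `COC(=O)C(Nc1cc(CS(=O)(=O)/C=C/c2c(OC)cc(OC)cc2OC)ccc1OC)c1ccc(Br)cc1`, gives 300 nM. These two numbers lie within the scatter of each other, so neither compound can be ranked above the other.

Compound 3 `COc1cc(OC)c(/C=C/S(=O)(=O)Cc2ccc(OC)c(NC(C(=O)O)c3ccc(Br)cc3)c2)c(OC)c1` differs from compound 2 in one place: bromo in place of fluoro on an aromatic carbon. This is bromo in place of fluoro on an aromatic carbon, para to a large group.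

Within the data shown here, only one measured step bears on this change, a 2.0-fold lower number from compound 1 to compound 2 (0.30 log units; within the scatter). That step exchanges bromo and fluoro, but it also replaces methoxycarbonyl with carboxy, so it cannot show what the exchange of bromo and fluoro does alone. Among the measured compounds shown here, no measured pair differs in that exchange only. For the measured compounds named here, the one step available stays within the scatter, so no clear direction can be drawn from it, and a change beyond the scatter is not expected in this assay.

Going by the values given here, the expected move is a 1.3-fold higher number from compound 2 to compound 3 (0.12 log units; within the scatter), which is no real step.

For compound 3, the estimated value is 200 nM, with an expected range of 70 nM to 550 nM.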

Compound 3, half-maximal inhibitory concentration: 300 nM
For compound 3 the middle estimate is 1.5-fold (0.18 log units) below the measured one; the range from low to high includes it.
By their numbers in this assay, from the lowest: compounds 2, 1 and 3 (each within the scatter of the next).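

In this assay, the exchange of fluoro for bromo on the aromatic carbon can now be read on its own, with nothing else altered, and it gives a 2.0-fold higher number from compound 2 to compound 3 (0.30 log units; within the scatter), so this swap does not separate from the ordinary spread of repeated measurements. The earlier step from compound 1 to compound 2 mixed two changes, and the second of them can now be read separately as well: hydrogen in place of methyl on the oxygen next to the carbonyl group, with the 4-bromophenyl group kept, gives no change at the digits printed from compound 1 to compound 3 (within the scatter). Each change taken alone therefore stays within the scatter, which the mixed step could not show, and no measurement at hand offers any explanation of these results.

Only fluoro and bromo are shown on this aromatic carbon, so it remains open how chloro, a nitrile or an amine there would read out. Only carboxy and methoxycarbonyl are shown on the carbon that carries this ring, so a primary amide in that spot also remains an open question.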